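Exchanging the isobutylpiperidinyl group for a methylpiperazinyl group

The source may report more compounds than this note shows. Statements on the series, on what has been measured and on what is new or still open speak of the compounds shown alone.

Three compounds share a core and differ at one aromatic carbon. Compound 1 `CN1CCC(c2ccc3c(c2)oc(=O)n3C(=O)NCCCCc2ccccc2)CC1=O` gives 105 nM in an assay on HEK293 cells for inhibition of acid ceramidase (Homo sapiens), read by fluorescence, with stated times of 10 min and 3 h; on this read-out lower numbers stand for stronger inhibition and higher numbers for weaker inhibition. Compound 2 `CN1CCN(c2ccc3c(c2)oc(=O)n3C(=O)NCCCCc2ccccc2)C(=O)C1` gives 52 nM in this assay. Compound 3 `CC(C)CN1CCC(c2ccc3c(c2)oc(=O)n3C(=O)NCCCCc2ccccc2)CC1` gives 120 nM in this assay, the highest number of the three, although its gap to compound 1 is within the scatter; the step of a 2.3-fold higher number from compound 2 to compound 3 (0.36 log units; beyond the scatter) is the only one beyond it. Compound 4 `CN1CCN(c2ccc3c(c2)oc(=O)n3C(=O)NCCCCc2ccccc2)CC1` carries the change (4-methylpiperazin-1-yl in place of 1-isobutylpiperidin-4-yl on an aromatic carbon). The steps of a 2.0-fold lower number from compound 1 to compound 2 (0.31 log units; beyond the scatter) and a 1.1-fold higher number from compound 1 to compound 3 (0.06 log units; within the scatter) bear on it: a nitrogen-linked ring with two heteroatoms gave the lowest number, while the oxo and isobutyl variations barely moved it. Compound 4 is therefore expected to give a modestly lower number, estimated at 70 nM (range 30 nM to 160 nM), a step of a 1.7-fold lower number from compound 3 to compound 4 (0.23 log units; within the scatter).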

Compound 4, half-maximal inhibitory concentration: 116 nM
For compound 4 the middle estimate is 1.7-fold (0.22 log units) below the measured one; low and high end bracket the measured number.
By their numbers in this assay, from the lowest: compound 2; then compounds 1, 4 and 3 (each within the scatter of the next).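

In this assay, a 1.0-fold lower number from compound 3 to compound 4 (0.01 log units; within the scatter) shows that 4-methylpiperazin-1-yl and 1-isobutylpiperidin-4-yl cannot be told apart at this aromatic carbon, and a 1.1-fold higher number from compound 1 to compound 4 (0.04 log units; within the scatter) adds no separation from compound 1. A six-membered ring with 2 hetero atoms is therefore not enough on its own: a 2.2-fold higher number from compound 2 to compound 4 (0.35 log units; beyond the scatter) accompanies the loss of the carbonyl of 4-methyl-2-oxopiperazin-1-yl, leaving compound 2 alone apart from the other three. No evidence is available to explain this difference. On these data alone, what a morpholine ring or an acetyl group on the piperazine nitrogen would give at this place remains open.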